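The compounds below may be only part of what the source reports. "The series", "measured", "known", "first", "only" and "open" are said of these compounds alone.

Compound 1 `CCN1CCN(c2cc(C)c3cc(NC(=O)c4ccccc4C)ccc3n2)CC1` gives 10900 nM in a functional assay on MCF7 cells (Homo sapiens) for antiproliferative activity, read by MTT assay, with a stated time of 72 h; a lower number here means a stronger inhibitor, a higher number a weaker inhibitor.
Compound 2 `CCc1ccc(C(=O)Nc2ccc3nc(N4CCN(CC)CC4)cc(C)c3c2)cc1` gives 3060 nM.
Compound 3 `CCN1CCN(c2cc(C)c3cc(NC(=O)c4cc(Cl)cc(Cl)c4)ccc3n2)CC1` gives 6090 nM.

All three compounds share one core and differ only in the group attached to the carbonyl carbon of the amide. Compound 3 has the second highest of the three numbers. Compound 3 sits within the scatter of both of the others: the two steps read a 1.8-fold lower number from compound 1 to compound 3 (0.25 log units; within the scatter) and a 2.0-fold higher number from compound 2 to compound 3 (0.30 log units; within the scatter).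

Compound 4 `CCN1CCN(c2cc(C)c3cc(NC(=O)c4cccc(Br)c4)ccc3n2)CC1` is not yet measured. It differs from compound 3 at the same position: 3-bromophenyl in place of 3,5-dichlorophenyl on a carbonyl carbon.

The steps already measured bear on this change, since each of them also swaps the group on the carbonyl carbon. The largest of them, a 3.6-fold lower number from compound 1 to compound 2 (0.55 log units; beyond the scatter), is modest; the other two stay within the scatter. Among the compounds with values here, a group with one halogen on the ring is exchanged for a group with two halogens, and nothing among the measured compounds points to a move beyond the scatter.

The expectation for compound 4 is therefore a 1.0-fold lower number from compound 3 to compound 4 (0.01 log units; within the scatter). Compound 4 is estimated at 6000 nM, with a range from 2500 nM to 14000 nM.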

Compound 4, half-maximal inhibitory concentration: 11600 nM
For compound 4 the middle estimate is 1.9-fold (0.29 log units) below the measured one, and the stated range covers the measured number.
By their numbers in this assay, from the lowest: compounds 2, 3, 1 and 4 (each within the scatter of the next, the first and the last beyond it).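

In this assay, replacing 3,5-dichlorophenyl with 3-bromophenyl on the carbonyl carbon gives a 1.9-fold higher number from compound 3 to compound 4 (0.28 log units; within the scatter), so this exchange of halogen-bearing rings does not separate the two compounds. The 3-bromophenyl and 2-methylphenyl groups also cannot be told apart here, with a 1.1-fold higher number from compound 1 to compound 4 (0.03 log units; within the scatter), while the 4-ethylphenyl group of compound 2 now stands apart from two of the other groups, with a 3.8-fold higher number from compound 2 to compound 4 (0.58 log units; beyond the scatter) alongside the earlier 3.6-fold lower number from compound 1 to compound 2 (0.55 log units; beyond the scatter), although compound 3 goes against this pattern by staying within the scatter of compound 2. The steps at this position therefore remain modest at most, and no measurement shown here explains why the 4-ethylphenyl group differs from the 3-bromophenyl and 2-methylphenyl groups.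

As far as these compounds go, all four compounds carry a phenyl ring with only halogen or small alkyl substituents, so it remains open how this position would respond to a ring bearing an amine or a carboxylic acid, or to a chain longer than ethyl. The core is also the same throughout, which leaves open whether these small differences would hold if another part of the molecule were changed.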